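A few compounds are considered here, and "the series" means these few. Any claim that something is new, unique, unknown or untested is made for them only; others in the source may bear on it.

In a functional assay on HepG2 cells (Homo sapiens) for antiproliferative activity, read by MTT assay, with a stated time of 72 h (on this read-out higher numbers stand for weaker inhibition and lower numbers for stronger inhibition), compound 3 `COc1cc2c(Nc3ccc(C#N)cc3)ncnc2cc1OCCCN1CCC(c2ccccc2)CC1` gives 4610 nM, the lowest number of the three measured. Compound 1 `COc1cc2c(Nc3ccc(C#N)cc3)ncnc2cc1OCCCN1CCC(O)CC1` gives 67900 nM, and compound 2 `CCOC(=O)C1CCN(CCCOc2cc3ncnc(Nc4ccc(C#N)cc4)c3cc2OC)CC1` gives 57700 nM. Compound 4 `COc1cc2c(Nc3ccc(C#N)cc3)ncnc2cc1OCCCN1CCC(N(C)C)CC1` carries dimethylamino in place of phenyl on a saturated ring carbon.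

Within the data shown here, three measured steps bear on this change. Phenyl in place of hydroxy gave a 15-fold lower number from compound 1 to compound 3 (1.17 log units; beyond the scatter), and phenyl in place of ethoxycarbonyl gave a 13-fold lower number from compound 2 to compound 3 (1.10 log units; beyond the scatter); both are large. Ethoxycarbonyl in place of hydroxy gave only a 1.2-fold lower number from compound 1 to compound 2 (0.07 log units; within the scatter). Among these compounds, then, the two without phenyl sit close together and compound 3 stands apart. Compound 4 also lacks phenyl, so a large move toward a higher number is expected, perhaps somewhat smaller than those two phenyl steps. Among the measured compounds shown here, no measured compound carries dimethylamino at this place, so the expectation stays wide. The expected change is a 7.6-fold higher number from compound 3 to compound 4 (0.88 log units; beyond the scatter). For compound 4 the estimate is 35000 nM, with an expected range of 11000 nM to 90000 nM.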

Compound 4, half-maximal inhibitory concentration: 33600 nM
The estimate for compound 4 lay 1.0-fold (0.02 log units) above the measured number, within the range that was stated.
By their numbers in this assay, from the lowest: compound 3; then compounds 4, 2 and 1 (each within the scatter of the next, the first and the last beyond it).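

In this assay, dimethylamino in place of phenyl at this ring carbon gave a 7.3-fold higher number from compound 3 to compound 4 (0.86 log units; beyond the scatter), so a third group without a ring, and the first here to bring in a nitrogen, also fails to keep the low number of the phenyl compound. Against the other two groups, dimethylamino gave a 1.7-fold lower number from compound 2 to compound 4 (0.23 log units; within the scatter) and a 2.0-fold lower number from compound 1 to compound 4 (0.31 log units; beyond the scatter), so the compounds without phenyl stay in one region, although the hydroxy and dimethylamino compounds lie just beyond the scatter of each other. Nothing measured here explains these differences.

The compounds shown leave open whether the aromatic ring itself goes with the lower number, which a cyclohexyl or pyridyl group at this place would test. They also leave open how a benzyl group or a carboxylic acid would read here.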